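A few compounds are considered here, and "the series" means these few. Any claim that something is new, unique, unknown or untested is made for them only; others in the source may bear on it.

Measured so far in a functional assay on HOS cells (Homo sapiens) for inhibition, with a stated time of 72 h; on this read-out lower numbers stand for stronger inhibition and higher numbers for weaker inhibition:
- compound 1 `NC1CCC(Nc2nc(NCc3ccc(-c4ccsc4)cc3)c3ncn(C4CCCC4)c3n2)CC1`: 120 nM
- compound 2 `NC1CCC(Nc2nc(NCc3ccc(-c4ccco4)nc3)c3ncn(C4CCCC4)c3n2)CC1`: 44 nM

Compound 2 has the lower of these two numbers. Compound 3 `Nc1ccccc1CNc1nc(NC2CCC(N)CC2)nc2c1ncn2C1CCCC1` is still unmeasured. The change leading to it is 2-aminophenyl in place of 6-(furan-2-yl)pyridin-3-yl on a saturated chain carbon bound to a nitrogen on an aromatic ring. Among the compounds with values here, only one measured step bears on this, made at the same place: a 2.7-fold lower number from compound 1 to compound 2 (0.44 log units; beyond the scatter). That step exchanged one two-ring group for another, so it is a weak guide to a single-ring group. With little certainty, a modest or somewhat larger rise in the number is expected, and the estimated step is a 5.7-fold higher number from compound 2 to compound 3 (0.75 log units; beyond the scatter). The estimated value for compound 3 is 250 nM, with an expected range of 50 nM to 1200 nM.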

Compound 3, half-maximal inhibitory concentration: 2030 nM
Beside the measured number, compound 3's estimate is 8.1-fold (0.91 log units) below it; measured number above the stated range.
By their numbers in this assay, from the lowest: compound 2; then compound 1; then compound 3.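

In this assay, swapping in 2-aminophenyl on this saturated chain carbon gives a 46-fold higher number from compound 2 to compound 3 (1.66 log units; beyond the scatter) and also a 17-fold higher number from compound 1 to compound 3 (1.23 log units; beyond the scatter). Both steps are large, whereas exchanging one two-ring group for another gave only a modest shift, so this position separates the single-ring group sharply from both two-ring groups. Nothing at hand explains this rise in the number. The change removes the second ring and adds an amino group together, and the compounds shown cannot separate the two. A plain phenyl group would help tell these apart.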